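The source may report more compounds than this note shows. Statements on the series, on what has been measured and on what is new or still open speak of the compounds shown alone.

Three compounds of the series have numbers in a functional assay on Raji cells (Homo sapiens) for cytotoxicity, read by CCK-8 assay, with a stated time of 24 h; a higher number here means a weaker inhibitor, a lower number a stronger inhibitor. Compound 1 `C=CC(=O)N1C(=O)CC(c2ccc(C(=O)OC)cc2)Sc2ccccc21` gives 89600 nM. Compound 2 `C=CC(=O)N1C(=O)CC(c2ccccc2Cl)Sc2ccccc21` gives 50400 nM. Compound 3 `C=CC(=O)N1C(=O)CC(c2ccc(-c3ccccc3)cc2)Sc2ccccc21` gives 56300 nM. Compound 3 thus stands second highest of the three numbers; compound 2 sits nearest to it and compound 1 furthest, and both gaps are within the scatter, so no order among the three can be read from them.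

Compound 4 `C=CC(=O)N1C(=O)CC(c2ccc(Cl)cc2)Sc2ccccc21` is not yet measured. It differs from compound 3 by chloro in place of phenyl on an aromatic carbon. Within the data shown here, the one measured step that bears on this position is a 1.6-fold lower number from compound 1 to compound 3 (0.20 log units; within the scatter), a change at the same aromatic carbon that stayed within the scatter. Among the measured compounds shown here, no measured compound carries chloro at this position; compound 2 carries a chloro group too, and its number and that of compound 3 lie within the scatter of each other. The expected step is therefore a 1.0-fold lower number from compound 3 to compound 4 (0.01 log units; within the scatter), with no movement beyond the scatter. Compound 4 is estimated at 55000 nM, within a range from 25000 nM to 120000 nM.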

Compound 4, half-maximal inhibitory concentration: 18400 nM
Compound 4: middle estimate off by 3.0-fold (0.48 log units), on the high side; the measured number lies below the stated range.
By their numbers in this assay, from the lowest: compound 4; then compounds 2, 3 and 1 (each within the scatter of the next).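

At the aromatic carbon para to a large group, the choice of substituent now moves the number beyond the scatter in this assay: chloro in place of phenyl gives a 3.1-fold lower number from compound 3 to compound 4 (0.49 log units; beyond the scatter) and chloro in place of methoxycarbonyl gives a 4.9-fold lower number from compound 1 to compound 4 (0.69 log units; beyond the scatter), whereas the earlier step between methoxycarbonyl and phenyl stayed within the scatter. The placement of the chloro also matters, as 4-chlorophenyl in place of 2-chlorophenyl on a saturated ring carbon gives a 2.7-fold lower number from compound 2 to compound 4 (0.44 log units; beyond the scatter), so the presence of a chloro group alone does not set the number. Nothing on hand accounts for these steps.

The compounds shown leave open whether a fluoro group, a methyl group, an amine or a carboxylic acid at this carbon would match chloro. Going by these compounds, all four numbers come from this assay alone, so whether this order holds in other cells also remains open.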